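Three limits, no numbers yet: compound 4 against compound 2

A few compounds are considered here, and "the series" means these few. Any claim that something is new, unique, unknown or untested is made for them only; others in the source may bear on it.

Measured so far:
compound 1 `C/N=C(/NC#N)NCCCCCn1nc(-c2ccccc2)c(C)cc1=O`: > 100 mg/kg
compound 2 `CC(C)C/N=C(\S)NCCCCn1nc(-c2ccccc2)ccc1=O`: > 100 mg/kg
compound 3 `C/N=C(/NC#N)NCCCCn1nc(-c2ccc(C)cc2)ccc1=O`: > 100 mg/kg

In a functional assay on the whole organism (stomach) with Rattus norvegicus as the target (a lower number here means that less compound is needed, a higher number that more compound is needed for the effect), compound 1 reaches only the limit of the assay, > 100 mg/kg. In this assay compound 2 likewise gives only a limit, > 100 mg/kg. For compound 3 this assay also returns a limit, > 100 mg/kg. So far every value is a limit and not a number: the limit of > 100 mg/kg in this assay, at which 3 of the 3 values shown sit. Compound 2 therefore stands nowhere in particular on a scale; it sits at the limit together with compound 1 and compound 3, and no ordering among the three can be read.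

Compound 4 `N#CNC(=N)NCCCCCn1nc(-c2ccccc2)ccc1=O` is the next member to be run in this assay. It differs from compound 2 in one place: a group of 7 heavy atoms (3 carbon, 4 nitrogen; no ring) in place of a group of 8 heavy atoms (5 carbon, 2 nitrogen, 1 sulfur; no ring), on a saturated chain carbon, four bonds along the chain from an aromatic nitrogen.

Going by the values given here, no measured step exists for this change. Because compound 1 and compound 3 sit at the same limit as compound 2 (the limit of > 100 mg/kg in this assay, at which 3 of the 3 values shown sit), no movement beyond the scatter is expected, and the step from compound 2 to compound 4 is estimated at a step that the limit leaves unreadable from compound 2 to compound 4. For compound 4 the expected value in this assay is 150 mg/kg, with a range from 60 mg/kg to 500 mg/kg, most likely reported again only as a limit.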

Compound 4, dose for half-maximal effect: > 100 mg/kg
Compound 4 ended at the assay's limit; the forecaster's own chance of this, stated with the estimate: 80%; the middle value lies beyond the limit too.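

Compound 4 gives > 100 mg/kg in this assay, again a limit and not a number. No step from compound 2 to compound 4 can be read, as both sit at the limit: the limit of > 100 mg/kg in this assay, at which 4 of the 4 values shown sit.

The compounds shown leave open what dose any member of this series needs in this assay.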